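Extending the methyl on the core of compound 1

The compounds below may be only part of what the source reports. "The series", "measured", "known", "first", "only" and "open" are said of these compounds alone.

Among the compounds with values here, compound 1 `COc1ccc2nc(C)cc(OCC(=O)Nc3cc(C)cc(C)c3)c2c1` is the only member of this small set for which a toxicity assay on HepG2 cells (Homo sapiens) for inhibition, read by CellTiter-Glo, with a stated time of 48 h (a higher number here means a weaker inhibitor, a lower number a stronger inhibitor), returns a number: in that assay compound 1 gives 20000 nM. The other two values are assay limits rather than numbers, namely (the limit of > 100000 nM in this assay, at which 2 of the 3 values shown sit). Compound 2 `Cc1cc(C)cc(NC(=O)COc2cc(C)nc3ccccc23)c1`, which carries hydrogen in place of methoxy on an aromatic carbon, reaches only the limit > 100000 nM in this assay. Compound 3 `CSc1ccc2nc(C)cc(OCC(=O)Nc3cc(C)cc(C)c3)c2c1`, with methylsulfanyl in place of methoxy on an aromatic carbon, likewise stops at the limit > 100000 nM in this assay. Those two changes read an at least 5.0-fold higher number from compound 1 to compound 2 (0.69 log units; beyond the scatter) and an at least 5.0-fold higher number from compound 1 to compound 3 (0.69 log units; beyond the scatter), while a step that the two limits leave unreadable from compound 2 to compound 3.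

Compound 4 `CCCc1cc(OCC(=O)Nc2cc(C)cc(C)c2)c2cc(OC)ccc2n1` differs from compound 1 elsewhere: ethyl in place of hydrogen on a saturated chain carbon bound to an aromatic carbon. Within the data shown here, none of the measured steps touches this chain; all three concern the aromatic carbon that carries methoxy in compound 1, and that methoxy is kept in compound 4. Among the measured compounds shown here, with no step to lean on, the change is expected to produce no step beyond the scatter in this assay, though the two limits in the set leave room for a weaker result. Compound 4 is therefore estimated at 30000 nM, within 8000 nM to 100000 nM. That estimate means a 1.5-fold higher number from compound 1 to compound 4 (0.18 log units; within the scatter) is expected.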

Compound 4, half-maximal inhibitory concentration: 12600 nM
Beside the measured number, compound 4's estimate is 2.4-fold (0.38 log units) above it; low and high end bracket the measured number.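

Within the data shown here, the new compound is the first to change the chain on the shared core, since every earlier step concerned the aromatic carbon that carries methoxy. In this assay, replacing hydrogen with ethyl on a saturated chain carbon bound to an aromatic carbon, which is the same as going from methyl to propyl, gives a 1.6-fold lower number from compound 1 to compound 4 (0.20 log units; within the scatter), so the two chains cannot be told apart at this place. Unlike the two replacements of methoxy, this change leaves a measured number rather than an assay limit, although nothing in the data shown accounts for that difference between the two places.

Whether the same holds for a longer chain such as butyl, for a cyclopropyl ring, or for a chain ending in an amine or a carboxylic acid stays open, since propyl is the only extension shown here. Also open is whether the propyl chain would return a number in this assay if it were combined with hydrogen or methylsulfanyl in place of methoxy, as the compounds shown carry the propyl chain only with methoxy kept.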